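The compounds below may be only part of what the source reports. "The series", "measured", "known", "first", "only" and "open" are said of these compounds alone.

Three thiopurine derivatives have been examined in a functional assay on FM3A cells (Homo sapiens) for inhibition, with FM3A (Mus musculus) as the target; a lower number here means a stronger inhibitor, a higher number a weaker inhibitor. Compound 1, `CC(=O)OC(C)n1cnc2c(S)nc(N)nc21`, gives 366000 nM there. Compound 3, `CC(=O)OC(C)n1cnc2c(S)nc(F)nc21`, gives 368000 nM in this assay; the change between the two is fluoro in place of amino on an aromatic carbon, and it produced a 1.0-fold higher number from compound 1 to compound 3 (0.00 log units; within the scatter). Compound 2, `CC(=O)OCCOn1cnc2c(S)nc(N)nc21`, carries a different side chain on the shared core, and the difference between the two cores is not broken down here; in this assay compound 2 gives 2000 nM, the lowest of the three numbers and beyond the scatter from both others.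

Compound 4, `CC(=O)OCCOn1cnc2c(S)nc(F)nc21`, is not yet measured. It relates to compound 2 by fluoro in place of amino on an aromatic carbon, the same change that took compound 1 to compound 3. Because that step was a 1.0-fold higher number from compound 1 to compound 3 (0.00 log units; within the scatter), the expectation for compound 4 in this assay is a step of no change at the digits printed from compound 2 to compound 4 (within the scatter) from compound 2. Compound 4 is therefore estimated at 2000 nM, with a range from 900 nM to 4500 nM.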

Compound 4, half-maximal inhibitory concentration: 136000 nM
Beside the measured number, compound 4's estimate is 68-fold (1.83 log units) below it; the whole stated range lies below it.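

Fluoro in place of amino on the aromatic carbon gave a large loss on the side chain of compound 2, with a 68-fold higher number from compound 2 to compound 4 (1.83 log units; beyond the scatter) in this assay. The size of the step did not carry over from one core to the other: the same change on two cores in this assay, a 1.0-fold higher number (0.00 log units; within the scatter) from compound 1 to compound 3 and a 68-fold higher number (1.83 log units; beyond the scatter) from compound 2 to compound 4, 68-fold (1.83 log units) apart, beyond the scatter of two such steps This shows that, in these two matched pairs, the effect of the change depends on the core, but with one pair per core it does not show which feature of the side chain is responsible.

The compounds shown leave open whether a step this large would recur on other side chains, such as a longer chain or one ending in a carboxylic acid. They also leave open how chloro or methylamino on that carbon would compare with amino and fluoro.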